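The compounds below may be only part of what the source reports. "The series", "measured", "known", "first", "only" and "open" are said of these compounds alone.

Compound 1 `O=S(=O)(NCCCNc1nccc(-c2c(-c3cccc(F)c3)nc3sccn23)n1)c1ccc(Br)cc1` belongs to a small set of three analogues sharing one core and differing only in the aryl group on the sulfonyl sulfur. In a functional assay on A-375 cells (Homo sapiens) for cytotoxicity, read by MTT assay (on this read-out lower numbers stand for stronger inhibition and higher numbers for weaker inhibition), compound 1 gives 7040 nM, the second highest of the three numbers. Compound 2 `O=S(=O)(NCCCNc1nccc(-c2c(-c3cccc(F)c3)nc3sccn23)n1)c1ccc(C(F)(F)F)cc1` gives 4090 nM and compound 3 `O=S(=O)(NCCCNc1nccc(-c2c(-c3cccc(F)c3)nc3sccn23)n1)c1cccc(F)c1` gives 13700 nM. The step of a 1.7-fold lower number from compound 1 to compound 2 (0.24 log units; within the scatter) stays inside the usual scatter, while a 3.3-fold higher number from compound 2 to compound 3 (0.52 log units; beyond the scatter) is a modest step beyond it, and a 1.9-fold higher number from compound 1 to compound 3 (0.29 log units; within the scatter) again falls within the scatter.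

Compound 4 `O=S(=O)(NCCCNc1nccc(-c2c(-c3cccc(F)c3)nc3sccn23)n1)c1ccccc1` differs from compound 1 by hydrogen in place of bromo on an aromatic carbon. The measured steps that bear on this are those altering the same aryl group: exchanging bromo for trifluoromethyl moved the number little, whereas moving from the 4-(trifluoromethyl)phenyl to the 3-fluorophenyl analogue raised it modestly. Within the data shown here, removing the bromo entirely has no direct precedent here, so only a small change is expected, and compound 4 is estimated at 10000 nM with a range from 4000 nM to 25000 nM, corresponding to an expected step of a 1.4-fold higher number from compound 1 to compound 4 (0.15 log units; within the scatter).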

Compound 4, half-maximal inhibitory concentration: 6600 nM
Compound 4: the middle estimate sits 1.5-fold (0.18 log units) above what was measured; the measured number falls inside the stated range.
By their numbers in this assay, from the lowest: compounds 2, 4, 1 and 3 (each within the scatter of the next, the first and the last beyond it).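

Removing the bromo leaves the number where it was, a 1.1-fold lower number from compound 1 to compound 4 (0.03 log units; within the scatter), and the step of a 1.6-fold higher number from compound 2 to compound 4 (0.21 log units; within the scatter) likewise shows no separation between the trifluoromethyl compound and the phenyl compound, so neither group on this aromatic carbon can be told apart from hydrogen. Among these compounds, the only new step beyond the scatter is the modest 2.1-fold lower number from compound 3 to compound 4 (0.32 log units; beyond the scatter), which sets the 3-fluorophenyl compound apart from the phenyl compound. Nothing available explains these numbers.

Going by these compounds, whether an amine or a carboxylic acid on the same aromatic carbon would stay as close to hydrogen as bromo and trifluoromethyl do remains open. On these data alone, it is also open whether fluoro on that same carbon would match compound 3 or compound 4, since the fluoro of compound 3 sits elsewhere on the ring.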